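Inverting a Stereocentre in a p300 Inhibitor Series

The source may report more compounds than this note shows. Statements on the series, on what has been measured and on what is new or still open speak of the compounds shown alone.

Of the compounds shown here, two have been measured. Compound 1 `COc1ccc(CCc2nc3cc(-c4c(C)noc4C)ccc3n2C2CCC(F)(F)CC2)cc1Cl` gives 83 nM in an assay on isolated protein for inhibition of histone acetyltransferase p300 (Homo sapiens), read by AlphaLISA, with a stated time of 20 min; on this read-out lower numbers stand for stronger inhibition and higher numbers for weaker inhibition. Compound 2 `COc1ccc(N2C(=O)C[C@H]2c2nc3cc(-c4c(C)noc4C)ccc3n2[C@H]2CC[C@H](OC)CC2)cc1Cl` gives 49 nM in this assay, the lower of the two numbers, though the gap to compound 1 lies within the scatter. Compound 3 `COc1ccc(N2C(=O)C[C@@H]2c2nc3cc(-c4c(C)noc4C)ccc3n2[C@H]2CC[C@H](OC)CC2)cc1Cl` is the stereoisomer: the two compounds have the same atoms and bonds and differ only in configuration as drawn: 2 of 3 stereo elements differ; a stereocentre at a saturated ring carbon is drawn S in compound 2 and R in compound 3; a stereocentre at a saturated ring carbon is drawn S in compound 2 and R in compound 3. Among the measured compounds shown here, no step between two measured compounds shows how such an inversion acts here, so the direction is not settled; a change in configuration is expected to weaken inhibition, giving a step of an 8.2-fold higher number from compound 2 to compound 3 (0.91 log units; beyond the scatter) beyond the scatter. Compound 3 is therefore estimated at 400 nM, within 80 nM to 3000 nM.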

Compound 3, half-maximal inhibitory concentration: 81 nM
The estimate for compound 3 lay 4.9-fold (0.69 log units) above the measured number; measured number inside the range.
By their numbers in this assay, from the lowest: compounds 2, 3 and 1 (each within the scatter of the next).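

Inverting two stereocentres at saturated ring carbons together gives a 1.7-fold higher number from compound 2 to compound 3 (0.22 log units; within the scatter) in this assay, so this read-out does not separate the two configurations. Compounds 1 and 2 could not show this, and the comparison here isolates configuration: the fact that compounds 2 and 3 differ only in the configuration as drawn

As far as these compounds go, what each stereocentre does when inverted alone remains open, since both change together in this pair. Also open, from the compounds shown here alone, is whether configuration would matter as little with an amine or a carboxylic acid in place of the methoxy group on the saturated ring.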